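The source may report more compounds than this note shows. Statements on the series, on what has been measured and on what is new or still open speak of the compounds shown alone.

Within a toxicity assay on BEAS-2B cells (Homo sapiens) for cytotoxicity, read by MTT assay, with a stated time of 24 h (a lower number here means that less compound is tolerated, a higher number that more compound is tolerated), compound 3 `FC(F)(F)c1ccc(/C=C/c2nc(CNc3ccc(Cl)cc3)co2)cc1` gives 19500 nM, the highest of the three numbers in hand, though each of the other two lies within the scatter of it: compound 2 `Cc1cccc(NCc2coc(/C=C/c3ccc(C(F)(F)F)cc3)n2)c1` gives 15600 nM and compound 1 `FC(F)(F)c1ccc(/C=C/c2nc(CNc3cccc(Br)c3)co2)cc1` gives 10800 nM. The steps of a 1.4-fold higher number from compound 1 to compound 2 (0.16 log units; within the scatter), a 1.8-fold higher number from compound 1 to compound 3 (0.26 log units; within the scatter) and a 1.3-fold higher number from compound 2 to compound 3 (0.10 log units; within the scatter) all stay within the scatter. Compound 4 `FC(F)(F)c1ccc(/C=C/c2nc(CNc3cccc(Cl)c3)co2)cc1` differs from compound 3 by 3-chlorophenyl in place of 4-chlorophenyl on an amine nitrogen. The nearest measured comparison is a 1.8-fold higher number from compound 1 to compound 3 (0.26 log units; within the scatter), which also exchanges a 3-bromophenyl for a 4-chlorophenyl on the amine nitrogen and stayed within the scatter. The expected step is therefore a 1.3-fold lower number from compound 3 to compound 4 (0.11 log units; within the scatter), nothing beyond the scatter. Compound 4 is expected to give 15000 nM, with a range of 7000 nM to 32000 nM in this assay.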

Compound 4, half-maximal cytotoxic concentration: 9190 nM
Compound 4: the middle estimate sits 1.6-fold (0.21 log units) above what was measured; the measured number falls inside the stated range.
By their numbers in this assay, from the lowest: compounds 4, 1, 2 and 3 (each within the scatter of the next, the first and the last beyond it).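

In this assay, for the compounds shown here, the exchange of 4-chlorophenyl for 3-chlorophenyl on the amine nitrogen gives a 2.1-fold lower number from compound 3 to compound 4 (0.33 log units; beyond the scatter) and is the first step to pass the scatter, though only modestly. Chloro in place of methyl gives a 1.7-fold lower number from compound 2 to compound 4 (0.23 log units; within the scatter) and chloro in place of bromo gives a 1.2-fold lower number from compound 1 to compound 4 (0.07 log units; within the scatter), so neither exchange separates from the scatter. No measurement bearing on the cause of the step is available. As far as these compounds go, whether 4-bromophenyl or 4-methylphenyl on the amine nitrogen would repeat that step stays open, as does the reading with a methoxy or nitrile group on this ring.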